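Carbamate change on a shared core, single-concentration inhibition notes

A few compounds are considered here, and "the series" means these few. Any claim that something is new, unique, unknown or untested is made for them only; others in the source may bear on it.

Measured so far:
Compound 1, `C[C@@H]1CN(C(=O)c2nc(Nc3cc(C4CC4)[nH]n3)c3cc(Cl)ccc3n2)CCN1C(=O)OCc1ccccc1`, gives 96% in an assay for inhibition of serine/threonine-protein kinase PAK 4 (Homo sapiens), read by FRET and Z'-LYTE, with a stated time of 60 min, tested at 50 uM, in the presence of a further agent that is not named here; a higher number here means a stronger effect of the compound at the concentration tested, a lower number a weaker effect.
Compound 2, `COC(=O)N1CCN(C(=O)c2nc(Nc3cc(C4CC4)[nH]n3)c3cc(Cl)ccc3n2)C[C@H]1C`, gives 98.5% in this assay.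

Of the two numbers in this assay, compound 2 gives the one at the high end, but the gap to compound 1, a number 2.5 percentage points higher from compound 1 to compound 2 (within the scatter), is within the scatter. Compound 3, `C[C@@H]1CN(C(=O)c2nc(Nc3cc(C4CC4)[nH]n3)c3cc(Cl)ccc3n2)CCN1C(=O)OCC(Cl)(Cl)Cl`, is not yet measured in this assay. It differs from compound 2 in one place: trichloromethyl in place of hydrogen on a saturated chain carbon bound to an oxygen next to a carbonyl group. Going by the values given here, the only step bearing on this place is a number 2.5 percentage points higher from compound 1 to compound 2 (within the scatter), which was within the scatter, and both measured numbers sit near the upper end of the read-out, so the expected step of a number 2.5 percentage points lower from compound 2 to compound 3 (within the scatter) is none beyond the scatter. Compound 3 is therefore estimated at 96%, with a range from 87% to 99.5%.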

Compound 3, a percentage reported as inhibition, at one concentration (the size of the read-out at that concentration, not a potency): 82.8%
Compound 3: the middle estimate sits 13.2 percentage points above what was measured, and the stated range ends above it.
By their numbers in this assay, from the lowest: compound 3; then compounds 1 and 2 (each within the scatter of the next).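

The group on the saturated chain carbon bound to an oxygen next to a carbonyl group can change the read-out in this assay: trichloromethyl in place of hydrogen gives a number 15.7 percentage points lower from compound 2 to compound 3 (beyond the scatter) and trichloromethyl in place of phenyl gives a number 13.2 percentage points lower from compound 1 to compound 3 (beyond the scatter) on the shared core. Hydrogen and phenyl had not separated at this place, so trichloromethyl is the first group here to stand apart from both. Nothing measured here explains this difference.

On these data alone, whether trifluoromethyl, a longer chain or an amine at this place would read like compound 3 or like compounds 1 and 2 remains open. These single-concentration readings also leave any potency differences among the compounds unresolved.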